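The source may report more compounds than this note shows. Statements on the series, on what has been measured and on what is new or still open speak of the compounds shown alone.

Of the compounds shown here, three that share a core have been tested in an assay on membranes from brain for binding affinity to adenosine receptor A1 (Rattus norvegicus), read by radioligand binding; on this read-out lower numbers stand for stronger inhibition and higher numbers for weaker inhibition. Compound 1 `Cc1nn(C)c2c(O)nc(Cc3ccccc3)nc12` gives 1310 nM in this assay. Compound 3 `Cc1nn(C)c2c(O)nc(-c3ccccc3)nc12` gives 1020 nM, and compound 2 `CCn1nc(C)c2nc(-c3ccccc3)nc(O)c21` gives 670 nM. The difference between the cores of compound 1 and compound 3 is not broken down here. Compound 3 and compound 2 differ in a single place, (methyl in place of hydrogen on a saturated chain carbon bound to an aromatic nitrogen), and that step made a 1.5-fold lower number from compound 3 to compound 2 (0.18 log units; within the scatter). The unmeasured compound 4 `CCn1nc(C)c2nc(Cc3ccccc3)nc(O)c21` is built from compound 1 by the same change, (methyl in place of hydrogen on a saturated chain carbon bound to an aromatic nitrogen). For the measured compounds named here, since the place of the change is described in the same words for both pairs, the step seen between compound 3 and compound 2 is the only guide to what compound 4 may show, and the number of compound 1 is the starting point. For compound 4 the step is expected to be a 1.5-fold lower number from compound 1 to compound 4 (0.16 log units; within the scatter), an expectation that rests on a 1.5-fold lower number from compound 3 to compound 2 (0.18 log units; within the scatter). Compound 4 is therefore expected to give about 900 nM in this assay, most likely between 400 nM and 2000 nM.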

Compound 4, half-maximal inhibitory concentration: 820 nM
The estimate for compound 4 lay 1.1-fold (0.04 log units) above the measured number; measured number inside the range.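

Replacing hydrogen with methyl at this place, which turns the methyl on the ring nitrogen into an ethyl, gave a 1.6-fold lower number from compound 1 to compound 4 (0.20 log units; within the scatter) in this assay, and this step matches the one seen on the other core: the same change on two cores in this assay, a 1.5-fold lower number (0.18 log units; within the scatter) from compound 3 to compound 2 and a 1.6-fold lower number (0.20 log units; within the scatter) from compound 1 to compound 4, 1.0-fold (0.02 log units) apart, within the scatter of two such steps. Within these two cores, then, the change carried over at the same size, and the step on one core was a fair guide to the step on the other. This does not show that the change really moves the number, since each step lies within the usual scatter of repeated measurements, and two cores are too few to support a rule for the whole series.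

Going by these compounds, it remains open whether a longer chain such as propyl, or a chain carrying an amine or a carboxylic acid, would shift the number beyond the scatter at this place. On these data alone, it also remains open whether a step of that kind would carry from one core to the other as closely as this one did.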